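A few compounds are considered here, and "the series" means these few. Any claim that something is new, unique, unknown or untested is made for them only; others in the source may bear on it.

Working notes on the sulfonamide series. Compound 1 `Cc1ccc(S(=O)(=O)N(CC(=O)NCc2ccc(Cl)cc2)c2ccccn2)cc1` is the parent; in a functional assay on CHO-K1 cells for antagonist activity at prostaglandin E2 receptor EP1 subtype (Homo sapiens), read by FLIPR and calcium flux (a higher number here means a weaker inhibitor, a lower number a stronger inhibitor), compound 1 gives < 1450 nM, which is a limit of the assay and not a number. Compound 2 `Cc1ccc(S(=O)(=O)N(CC(=O)NCc2ccc(Cl)cc2)c2ncccc2C)cc1` carries a methyl on an aromatic carbon. In this assay compound 2 gives < 1450 nM, again a limit. Compound 3 `Cc1ccc(S(=O)(=O)N(CC(=O)NCc2ccc(Cl)cc2)c2ccc(C)nc2)cc1` has 6-methylpyridin-3-yl on the sulfonamide nitrogen. In this assay compound 3 gives < 1450 nM, a limit as well. Compound 3 therefore stands where every measured member stands, at the limit of < 1450 nM in this assay, at which 3 of the 3 values shown sit; no ordering among the three is readable.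

The next member, compound 4 `Cc1ccc(S(=O)(=O)N(CC(=O)NCc2ccc(Cl)cc2)c2ccc(C)cn2)cc1`, differs from compound 3 by 5-methylpyridin-2-yl in place of 6-methylpyridin-3-yl on a sulfonamide nitrogen. The measured steps that bear on this change are a step that the two limits leave unreadable from compound 1 to compound 3, a step that the two limits leave unreadable from compound 2 to compound 3 and a step that the two limits leave unreadable from compound 1 to compound 2, all of them swaps of the pyridyl group or of a methyl on it, and none of them readable in size. Among the measured compounds shown here, nothing shows that moving the methyl or the ring nitrogen shifts potency beyond the scatter, so no step of readable size is expected in this assay, and compound 4 is expected to sit where its analogues sit.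

Compound 4 is expected to give 500 nM in this assay, within 60 nM to 1450 nM, with the expected step that the limit leaves unreadable from compound 3 to compound 4 being none beyond the scatter.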

Compound 4, inhibition constant: < 1450 nM
Compound 4 ended at the assay's limit; the forecaster's own chance of this, stated with the estimate: 70%; the middle value is on the limit's open side.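

In this assay compound 4 gives < 1450 nM, a limit of the assay and not a number. No step among compound 1, compound 2, compound 3 and compound 4 can be read, because all four share one limit: the limit of < 1450 nM in this assay, at which 4 of the 4 values shown sit.

The compounds shown leave open whether these pyridyl swaps on the sulfonamide nitrogen change potency at all, and how the four compounds order.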